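Fluoro next to the ring nitrogen of compound 1

The source may hold more compounds than are shown below. What is called first, only, known or untested is meant among the compounds shown, and "the series" means these compounds.

Measured so far:
compound 1, `Cc1cc(-c2ccc(=O)n(C)c2)cc2cn(C3CCNCC3)nc12`, 320 nM
compound 2, `Cc1cc(-c2cc(C)c3nn(C4CCNCC4)cc3c2)cn(C)c1=O`, 33 nM
compound 3, `Cc1cc(=O)n(C)cc1-c1cc(C)c2nn(C3CCNCC3)cc2c1`, 76 nM

In an assay on PBMC cells for antagonist activity at Toll-like receptor 8 (Homo sapiens), read by HTRF, with stated times of 30 min and 20 h (on this read-out lower numbers stand for stronger inhibition and higher numbers for weaker inhibition), compound 1 gives the highest of the three numbers. Compound 3 lies nearest, with a 4.2-fold lower number from compound 1 to compound 3 (0.62 log units; beyond the scatter), and compound 2 lies furthest, with a 9.7-fold lower number from compound 1 to compound 2 (0.99 log units; beyond the scatter). Both of those steps put a methyl on an aromatic carbon of the same six-membered ring that carries the ring nitrogen, and both lowered the number beyond the scatter.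

Compound 4, `Cc1cc(-c2ccc(=O)n(C)c2F)cc2cn(C3CCNCC3)nc12`, differs from compound 1 by fluoro in place of hydrogen on an aromatic carbon. The change is on the same ring as the two methyl steps, but at a different position and with a different group, so the methyl steps bear on it only loosely: they show that a small group added to that ring lowered the number in two places, and nothing measured here shows an increase. Among the measured compounds shown here, a step of the same direction but smaller size is therefore expected in this assay, since fluoro is not methyl and no fluoro step has been measured. Compound 4 is estimated at 150 nM, within 50 nM to 500 nM, which corresponds to an expected step of a 2.1-fold lower number from compound 1 to compound 4 (0.33 log units; beyond the scatter).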

Compound 4, half-maximal inhibitory concentration: 13 nM
Compound 4: middle estimate off by 12-fold (1.06 log units), on the high side; measured number below the stated range.
By their numbers in this assay, from the lowest: compound 4; then compound 2; then compound 3; then compound 1.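

In this assay, fluoro in place of hydrogen next to the ring nitrogen gives a 25-fold lower number from compound 1 to compound 4 (1.39 log units; beyond the scatter), and this is the only large step on this ring among the compounds shown. The two methyl steps, a 9.7-fold lower number from compound 1 to compound 2 (0.99 log units; beyond the scatter) and a 4.2-fold lower number from compound 1 to compound 3 (0.62 log units; beyond the scatter), are both modest. The earlier compounds shown here showed only that methyl on other carbons of this ring lowered the number, whereas this result shows that a change of a single heavy atom, on a carbon ortho to a large group and ortho to a methyl group, can produce a much bigger step than those results suggested. Nothing available here explains the size of this step.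

The compounds shown leave open whether chloro, methoxy or a nitrile on this same carbon would lower the number as fluoro does, or whether the step is particular to fluoro. They also leave open whether fluoro on this carbon would lower the number in the same way when combined with the methyl groups of compound 2 or compound 3.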